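Nitro to Amino on a Second Core: Cytotoxicity Outlook

A few compounds are considered here, and "the series" means these few. Any claim that something is new, unique, unknown or untested is made for them only; others in the source may bear on it.

Compound 1 `COc1ccc(-c2nc3cc(Cl)c(Cl)cc3[nH]2)c([N+](=O)[O-])c1` and compound 3 `COc1ccc(-c2nc3cc(Cl)c(Cl)cc3[nH]2)c(N)c1` share a core and differ only by amino in place of nitro on an aromatic carbon. In an ADME assay on MDBK cells (Bos taurus) for cytotoxicity, read by MTT assay, with a stated time of 96 h (on this read-out higher numbers stand for lower toxicity in this test and lower numbers for higher toxicity in this test), compound 1 gives 28000 nM, and compound 3 gives 6500 nM; the step is a 4.3-fold lower number from compound 1 to compound 3 (0.63 log units; beyond the scatter). Compound 2 `O=[N+]([O-])c1ccc(-c2nc3cc(C(F)(F)F)ccc3n2C2CCCCC2)cc1` rests on a different core; the difference between the two cores is not broken down here. In this assay compound 2 gives 68000 nM, the highest of the three numbers. Compound 4 `Nc1ccc(-c2nc3cc(C(F)(F)F)ccc3n2C2CCCCC2)cc1` differs from compound 2 by amino in place of nitro on an aromatic carbon. This is the same kind of change as that from compound 1 to compound 3, though there the amino sits ortho to a large group and meta to a methoxy group, here para to a large group. Compound 4 is therefore expected to show a step of a 3.8-fold lower number from compound 2 to compound 4 (0.58 log units; beyond the scatter), resting on the step from compound 1 to compound 3 of a 4.3-fold lower number from compound 1 to compound 3 (0.63 log units; beyond the scatter). The estimate for compound 4 is 18000 nM, between 7000 nM and 45000 nM.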

Compound 4, half-maximal cytotoxic concentration: > 100000 nM
Compound 4: only a limit was reported; the forecaster's own chance of this, stated with the estimate: 15%; at least 5.5-fold (0.74 log units) between middle value and limit.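

In this assay the change from nitro to amino does not carry over from the core of compound 1 to the core of compound 2: the same change on two cores in this assay, a 4.3-fold lower number (0.63 log units; beyond the scatter) from compound 1 to compound 3 and an at least 1.4-fold higher number (0.16 log units; that floor lies within the scatter) from compound 2 to compound 4, at least 6.3-fold (0.80 log units) apart, beyond the scatter of two such steps. Compound 4 gives > 100000 nM as a limit of the assay and not as a number. That leaves an at least 1.4-fold higher number from compound 2 to compound 4 (0.16 log units; that floor lies within the scatter) as a floor only, so the two pairs show that the step on one core cannot be assumed on the other, but not how large the second step is or what in the cores sets the gap.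

The compounds shown leave open which part of the two cores matters. Also open, from the compounds shown here alone, is how a dimethylamino or an acetamido group in place of amino would read on either core.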